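Methoxy Entering the Phenyl Ring of Compound 2

The source may hold more compounds than are shown below. What is called first, only, known or untested is meant among the compounds shown, and "the series" means these compounds.

Measured so far:
compound 1 `COc1ccc(-c2nc(C)c(C(=O)CSc3nc(-c4cccc(OC)c4)c(C#N)c(=O)[nH]3)s2)cc1` — 71.3%
compound 2 `Cc1nc(-c2ccccc2)sc1C(=O)CSc1nc(-c2ccc(Cl)c(Cl)c2)c(C#N)c(=O)[nH]1` — 98.6%

In a functional assay on U-87MG ATCC cells for antiproliferative activity against U-87 MG (Homo sapiens), read by MTT assay, with a stated time of 48 h, tested at 5 uM (on this read-out lower numbers stand for a stronger effect and higher numbers for a weaker effect at the one concentration tested), compound 2 stands highest of the two numbers; its nearest neighbour, compound 1, reads lower by a margin beyond the scatter, so compound 2 is the weaker of the two on this read-out.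

Compound 3 `COc1ccc(-c2nc(C)c(C(=O)CSc3nc(-c4ccc(Cl)c(Cl)c4)c(C#N)c(=O)[nH]3)s2)cc1` is not yet measured. It differs from compound 2 by methoxy in place of hydrogen on an aromatic carbon. For the measured compounds named here, no step between measured compounds that differ in one place is available, and compound 1, which also carries a methoxy group, differs from compound 2 at a second position as well; its value shows only that a methoxy-bearing analogue can read lower, not what the methoxy alone contributes.

The expectation is a modest downward step, a number 13.6 percentage points lower from compound 2 to compound 3 (beyond the scatter), which may or may not exceed the scatter. Compound 3 is estimated at 85%, with a range from 62% to 100%.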

Compound 3, a percentage reported as activity, at one concentration (the size of the read-out at that concentration, not a potency): 101%
Compound 3: middle estimate off by 16 percentage points, on the low side, and the stated range ends below it.
By their numbers in this assay, from the lowest: compound 1; then compounds 2 and 3 (each within the scatter of the next).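

In this assay, phenyl to 4-methoxyphenyl gives a number 2.4 percentage points higher from compound 2 to compound 3 (within the scatter) and so does not separate the two compounds at the one concentration tested. With 4-methoxyphenyl held constant, 3,4-dichlorophenyl in place of 3-methoxyphenyl gives a number 29.7 percentage points higher from compound 1 to compound 3 (beyond the scatter) in the same assay, which ties the lower number of compound 1 to that group and not to the methoxy on the other phenyl ring. No measurement on hand gives a cause for either step.

From the compounds shown here alone, whether phenyl to 4-methoxyphenyl also reads flat alongside 3-methoxyphenyl stays open, as compound 1 has no single-change partner for that comparison. Also open, going by these compounds, is how an amine, a carboxylic acid or a longer alkoxy chain would read in the place of methoxy, para to a large group.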